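A few compounds are considered here, and "the series" means these few. Any claim that something is new, unique, unknown or untested is made for them only; others in the source may bear on it.

Compound 1 `ClCc1ccccc1Cn1cnc2c(Cl)nc(Cl)nc21` and compound 2 `ClCc1cccc(Cn2cnc3c(Cl)nc(Cl)nc32)c1` are built from the same atoms joined differently; how their two cores differ is not broken down here. In a functional assay on NCI-H23 cells (Homo sapiens) for cytotoxicity, read by sulforhodamine B assay, with a stated time of 48 h (a higher number here means a weaker inhibitor of growth, a lower number a stronger inhibitor of growth), compound 1 gives 3090 nM, and compound 2 gives 5120 nM, the two lying within the usual scatter of each other. Compound 3 `Nc1nc(Cl)c2ncn(Cc3ccccc3CCl)c2n1` arises from compound 1 by a single change amino in place of chloro on an aromatic carbon and in this assay compound 3 gives 8910 nM, which amounts to a 2.9-fold higher number from compound 1 to compound 3 (0.46 log units; beyond the scatter). Compound 4 `Nc1nc(Cl)c2ncn(Cc3cccc(CCl)c3)c2n1` is not yet measured; it arises from compound 2 by the same change amino in place of chloro on an aromatic carbon at a place described in the same words. Going by the values given here, the step from compound 2 to compound 4 in this assay is expected to be about a 2.5-fold higher number from compound 2 to compound 4 (0.40 log units; beyond the scatter), resting only on the single earlier step of a 2.9-fold higher number from compound 1 to compound 3 (0.46 log units; beyond the scatter). Compound 4 is therefore expected to give about 13000 nM, between 6000 nM and 30000 nM.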

Compound 4, concentration for total growth inhibition: 5010 nM
Compound 4: middle estimate off by 2.6-fold (0.41 log units), on the high side, and the stated range ends above it.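

In this assay, amino in place of chloro on an aromatic carbon gives a 1.0-fold lower number from compound 2 to compound 4 (0.01 log units; within the scatter) and so does not repeat the earlier result on the other core, as the two steps set side by side make plain: the same change on two cores in this assay, a 2.9-fold higher number (0.46 log units; beyond the scatter) from compound 1 to compound 3 and a 1.0-fold lower number (0.01 log units; within the scatter) from compound 2 to compound 4, 2.9-fold (0.47 log units) apart, beyond the scatter of two such steps
This shows that a step measured on one core cannot simply be carried over to another core in this series. It does not show why the two cores respond differently, and two pairs are too few to support a rule for any further core.

The compounds shown leave open how a methylamino or methoxy group at the same ring carbon would behave on either core. They also leave open what a hydroxymethyl group in place of the chloromethyl group would do.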